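The compounds below may be only part of what the source reports. "The series", "measured", "known", "first", "only" and "open" are said of these compounds alone.

Compound 1, `COc1ncnc2c1c(I)cn2[C@@H]1O[C@H](CO)[C@@H](O)[C@H]1O`, gives > 20000 nM in a functional assay on HCT-116 cells (Homo sapiens), read by MTT assay, with a stated time of 72 h; a higher number here means a weaker inhibitor, a lower number a stronger inhibitor; this is a limit of the assay, not a number.
Compound 2, `COc1nc(N)nc2c1c(-c1ccco1)cn2[C@@H]1O[C@H](CO)[C@@H](O)[C@H]1O`, gives > 20000 nM in this assay; this too is a limit.
Compound 3, `CNc1ncnc2c1c(-c1ccco1)cn2[C@@H]1O[C@H](CO)[C@@H](O)[C@H]1O`, gives 440 nM in this assay.

Among the compounds with values here, compound 3 therefore holds the only number in the set; the other two values are limits. Compound 4, `COc1ncnc2c1c(-c1ccco1)cn2[C@@H]1O[C@H](CO)[C@@H](O)[C@H]1O`, is not yet measured. It differs from compound 3 by methoxy in place of methylamino on an aromatic carbon. Compound 1 and compound 2 both carry a methoxy at that place and both give only limits, while compound 3 with methylamino gives a number. A weakening step is expected, beyond the scatter, with a fair chance that only a limit is reported. For compound 4 the estimated value is 8000 nM, in a range from 1500 nM to 30000 nM. The expected step is an 18-fold higher number from compound 3 to compound 4 (1.26 log units; beyond the scatter), upward.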

Compound 4, half-maximal inhibitory concentration: 40 nM
Compound 4: middle estimate off by 200-fold (2.30 log units), on the high side, and the stated range ends above it.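

In this assay methoxy in place of methylamino gives an 11-fold lower number from compound 3 to compound 4 (1.04 log units; beyond the scatter) and so shows that methoxy on this aromatic carbon is compatible with strong inhibition. With methoxy kept, hydrogen in place of amino gives an at least 500-fold lower number from compound 2 to compound 4 (2.69 log units; beyond the scatter) and furan-2-yl in place of iodo gives an at least 500-fold lower number from compound 1 to compound 4 (2.69 log units; beyond the scatter) so the amino and iodo changes each separate a limit from a number. The values of compound 1 and compound 2 are limits of the assay, not numbers: the limit of > 20000 nM in this assay, at which 2 of the 4 values shown sit.

Open, from the compounds shown here alone, is whether ethoxy or a longer chain at this place holds the gain. Also open, going by these compounds, is whether a free amino group there, or a phenyl ring in place of furan-2-yl, would do the same.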